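Swapping the aryl group on the triazole's benzyl arm

This account rests on a few compounds, and the source may have more. Where it says the series, first, only, none or still open, it means among the compounds named here.

Compound 1, `N#Cc1ccc(Cn2cc(C[C@H](O)COCCOC[C@@H](O)Cc3ccc(-c4ccccc4)cc3)nn2)cc1`, is the reference point here. In a functional assay on SGC-7901 cells (Homo sapiens) for inhibition, read by MTT assay, with a stated time of 72 h (on this read-out lower numbers stand for stronger inhibition of growth and higher numbers for weaker inhibition of growth), compound 1 gives 7700 nM, which is the lowest of the two numbers shown, with compound 2 nearest. Compound 2, `O=C1COc2ccc(-n3cc(C[C@H](O)COCCOC[C@@H](O)Cc4ccc(-c5ccccc5)cc4)nn3)cc2N1`, gives 15200 nM in this assay. Compound 3, `O[C@H](COCCOC[C@@H](O)Cc1cn(-c2cncnc2)nn1)Cc1ccc(-c2ccccc2)cc1`, reaches only the limit of > 100000 nM in this assay, as noted in the limit of > 100000 nM in this assay, at which 1 of the 3 values shown sits.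

Compound 4, `O[C@H](COCCOC[C@@H](O)Cc1cn(Cc2cccc(-c3ccccc3)c2)nn1)Cc1ccc(-c2ccccc2)cc1`, is not yet measured. It differs from compound 1 by 3-phenylphenyl in place of 4-cyanophenyl on a saturated chain carbon bound to an aromatic nitrogen.

Going by the values given here, two measured steps bear on this. The step of a 2.0-fold higher number from compound 1 to compound 2 (0.30 log units; within the scatter) also changes the group on the aromatic nitrogen of the shared core while keeping an aromatic ring there, and it stayed within the scatter. The step of an at least 12-fold higher number from compound 1 to compound 3 (1.11 log units; beyond the scatter) was large, but it removed the 4-cyanobenzyl group altogether and put a small heteroaromatic ring directly on the nitrogen; compound 4 keeps the saturated chain carbon and a carbon-only aromatic ring, so that step is a weaker guide. Replacing one aromatic ring by a larger one on this arm is therefore expected to move the number little, if at all, beyond the scatter.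

Compound 4 is thus estimated at 7000 nM, within 2500 nM to 20000 nM, meaning an expected step of a 1.1-fold lower number from compound 1 to compound 4 (0.04 log units; within the scatter).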

Compound 4, concentration for 50% growth inhibition: 10600 nM
Compound 4: the middle estimate sits 1.5-fold (0.18 log units) below what was measured; measured number inside the range.
By their numbers in this assay, from the lowest: compounds 1, 4 and 2 (each within the scatter of the next). At a limit, above all of these: compound 3.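

In this assay, the swap gives a 1.4-fold higher number from compound 1 to compound 4 (0.14 log units; within the scatter), so this place accepts 3-phenylphenyl, with two aromatic rings, in place of 4-cyanophenyl, with one aromatic ring. The earlier compounds shown here did not show this, as none of them keeps the saturated chain carbon bound to the aromatic nitrogen while changing only the aromatic group on it; here the nitrile and its hydrogen-bond acceptor are gone and the number stays within the scatter, so in this pair the nitrile is not needed to hold the growth inhibition. Compound 3 still stands apart from the other three, and its value is a limit: the limit of > 100000 nM in this assay, at which 1 of the 4 values shown sits.

On these data alone, it remains open whether an amine or a carboxylic acid on this aromatic ring, or a plain phenyl carrying neither a nitrile nor a second ring, would keep the number in the same range. As far as these compounds go, it is also open whether a longer chain in place of the saturated chain carbon would move the number beyond the scatter.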